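The source may report more compounds than this note shows. Statements on the series, on what has been measured and on what is new or still open speak of the compounds shown alone.

Measured compounds:
- compound 1 `O=S(=O)(c1cccc(-c2ccc3nccc(-c4ccncc4)c3n2)c1)N1CCC(O)CC1`: 10000 nM
- compound 2 `O=S(=O)(c1cccc(Nc2ccc3nccc(-c4ccncc4)c3n2)c1)N1CCCC1`: < 5000 nM
- compound 3 `O=S(=O)(NCCO)c1cccc(Nc2ccc3nccc(-c4ccncc4)c3n2)c1`: 115000 nM

In a physicochemical assay for solubility, read by HPLC, using the shake flask method, measured as kinetic solubility, with a stated time of 20 h, at pH 6.5, tested at 200 uM (a higher number here means a more soluble compound, a lower number a less soluble compound), compound 1 gives 10000 nM, the lowest of the two numbers shown; compound 3 gives 115000 nM. For compound 2 the result is only a limit of this assay, (the limit of < 5000 nM in this assay, at which 1 of the 3 values shown sits). The step from compound 1 to compound 4 `CS(=O)(=O)c1cccc(-c2ccc3nccc(-c4ccncc4)c3n2)c1` is methyl in place of 4-hydroxypiperidin-1-yl on a sulfonyl sulfur. Among the measured compounds shown here, no measured step repeats this change. For the measured compounds named here, the one measured step on the same sulfonyl sulfur, an at least 23-fold higher number from compound 2 to compound 3 (1.36 log units; beyond the scatter), runs from a ring without a hydroxyl to an open group that carries one, and it is large. The change from compound 1 to compound 4 goes the other way, from a group with a hydroxyl to a methyl, so compound 4 is expected to sit somewhat lower than compound 1 in this assay, though the comparison is indirect. The estimated step is a 2.5-fold lower number from compound 1 to compound 4 (0.40 log units; beyond the scatter). For compound 4 the expected value is 4000 nM, within 1000 nM to 16000 nM, with a fair chance that this assay reports only a limit.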

Compound 4, solubility: < 5000 nM
Compound 4 was reported as a limit; the forecaster's own chance of this, stated with the estimate: 45%; the middle value lies beyond the limit too.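

In this assay the methyl in place of 4-hydroxypiperidin-1-yl on the sulfonyl sulfur gives an at least 2.0-fold lower number from compound 1 to compound 4 (0.30 log units; that floor lies within the scatter) and so can be read only as a floor. Compound 4 is a limit and not a number, and the floor alone does not separate it from compound 1 beyond the scatter, although the direction of the printed step is downward. With this result a second compound ends at the same limit, now on the core of compound 1 as well: the limit of < 5000 nM in this assay, at which 2 of the 4 values shown sit.

The compounds shown leave open how far the true value of compound 4 lies beyond its limit, so the full size of the step stays unknown. They also leave open how a carboxylic acid or a longer chain ending in an amine on the sulfonyl sulfur would read in this assay on the core of compound 1.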